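The source may hold more compounds than are shown below. What is called first, only, known or untested is meant among the compounds shown, and "the series" means these compounds.

Working notes on the series.

Among the compounds with values here, compound 1 `COc1cc(OC)cc(-n2c(-c3ccccc3)nc(C)c2C)c1` is measured in a functional assay, with a stated time of 15 min, tested at 60 uM (on this read-out lower numbers stand for a weaker effect and higher numbers for a stronger effect at the one concentration tested), and gives 53.3%, which places it second highest of the three numbers so far. Compound 3 `COc1ccc(-n2c(-c3ccccc3)nc(C)c2C)cc1` gives 64.9% in this assay, and compound 2 `COc1ccc(-n2c(-c3ccc(F)cc3)nc(C)c2C)cc1` gives 41.9%; compound 1 stands between the two, and both gaps to compound 1 lie beyond the scatter.

Within the data shown here, one measured step bears directly on the next compound: a number 23 percentage points higher from compound 2 to compound 3 (beyond the scatter). Compound 4 `COc1cc(OC)cc(-n2c(-c3ccc(F)cc3)nc(C)c2C)c1` is the analogue of compound 1 carrying the reverse of that change, (fluoro in place of hydrogen on an aromatic carbon). Cut one bond further out, the change reads phenyl to 4-fluorophenyl, the same pair of groups as between compound 3 and compound 2, only on the other core substitution pattern.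

On that single precedent a drop beyond the scatter is expected in this assay, of about the size seen from compound 2 to compound 3 but in the opposite direction, and so the step of a number 21.3 percentage points lower from compound 1 to compound 4 (beyond the scatter) is the estimate here. Compound 4 is therefore expected to give 32% in this assay, within the range 15% to 48%.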

Compound 4, a percentage reported as activity, at one concentration (the size of the read-out at that concentration, not a potency): 60%
Estimate against measurement, compound 4: 28 percentage points below; measured number above the stated range.
By their numbers in this assay, from the lowest: compound 2; then compounds 1, 4 and 3 (each within the scatter of the next, the first and the last beyond it).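

Phenyl to 4-fluorophenyl does not carry a single outcome from one core to the other in this assay. On the core of compound 1, fluoro on this aromatic carbon, para to a large group, gives a number 6.7 percentage points higher from compound 1 to compound 4 (within the scatter), so the loss seen on the other core does not appear here. The size of this change at this place therefore cannot be transferred between the two cores, and one step on one core is a poor guide to the other: the same change on two cores in this assay, a number 23 percentage points higher (beyond the scatter) from compound 2 to compound 3 and a number 6.7 percentage points lower (within the scatter) from compound 4 to compound 1, 29.7 percentage points apart, beyond the scatter of two such steps

The compounds shown compare only hydrogen and fluoro at this place, so how an amine or a carboxylic acid there would read on either core remains open. Each number also comes from a single concentration, which leaves the potency of all these compounds unknown.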